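A fluoro step from compound 2 at the limit

This account rests on a few compounds, and the source may have more. Where it says the series, first, only, none or still open, it means among the compounds named here.

Measured in a functional assay on A-375 cells (Homo sapiens) for antiproliferative activity, read by MTT assay, with a stated time of 72 h; a lower number here means a stronger inhibitor, a higher number a weaker inhibitor:
Compound 1 `COc1cccc(N2C(=O)COc3ccc(-c4cccc(NS(=O)(=O)c5ccc(F)cc5)c4)cc32)c1` gives > 40000 nM
Compound 2 `O=C1COc2ccc(-c3cccc(NS(=O)(=O)c4ccc(F)cc4)c3)cc2N1c1ccccc1` gives > 40000 nM
Compound 3 `O=C1COc2ccc(-c3ccc(O)cc3)cc2N1` gives > 40000 nM
Compound 4 `O=C1COc2ccc(-c3cccc(NS(=O)(=O)c4ccc(F)cc4)c3)cc2N1c1ccc(F)cc1` has no value yet

The picture so far is the limit of > 40000 nM in this assay, at which 3 of the 3 values shown sit, and no measured number lies below it. Each of the three entries is a limit of the assay and not a number. Compound 2 stands at the limit > 40000 nM and has no exact place in the series.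

Compound 4 differs from compound 2 by a single change, fluoro in place of hydrogen on an aromatic carbon, para to a large group, which turns phenyl into 4-fluorophenyl (fluoro in place of hydrogen on an aromatic carbon). Going by the values given here, the one measured step that bears on this change is a step that the two limits leave unreadable from compound 1 to compound 2 and it also alters a single group on an aromatic carbon. That step has no readable size to carry over, and for that reason no step beyond the scatter, in either direction, is expected in this assay for the fluoro change.

The expected step is a number no higher from compound 2 to compound 4 (the limit leaves the size open) and a further limit is the likeliest report. For compound 4 the estimate is 40000 nM with an expected range from 15000 nM to 80000 nM in this measurement.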

Compound 4, half-maximal inhibitory concentration: > 40000 nM
Compound 4 ended at the assay's limit; the forecaster's own chance of this, stated with the estimate: 75%; the middle value sits exactly at the limit.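

In this assay compound 4 gives > 40000 nM, which is a limit of the assay and not a number. Neither the step from compound 2 to compound 4 nor that from compound 1 to compound 4 can be read. The compounds shown leave open whether fluoro in place of hydrogen changes antiproliferative activity at all.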